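A few compounds are considered here, and "the series" means these few. Any claim that something is new, unique, unknown or untested is made for them only; others in the source may bear on it.

Of the compounds shown here, three have a measured value so far in a functional assay on A2780 cells (Homo sapiens) for antiproliferative activity, read by MTT assay, with a stated time of 48 h; on this read-out higher numbers stand for weaker inhibition and lower numbers for stronger inhibition. Compound 1 (`COc1ccc(C(=O)c2ccc(OC)c3c2OC(C)(C)C=C3)c(NC(=O)CBr)c1`) gives 980 nM there, compound 2 (`COc1ccc(C(=O)c2ccc3c(c2)C=CC(C)(C)O3)c(NC(=O)CBr)c1`) gives 1870 nM and compound 3 (`COc1ccc(C(=O)c2ccc(OC)c3c2C=CC(C)(C)O3)c(NC(=O)CN)c1`) gives 890 nM in the same test. Compound 2 cannot be told apart from compound 1, since the gap between them lies within the usual scatter of repeated measurements, whereas compound 3 reads lower, just beyond that scatter.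

Compound 4 (`CCNCC(=O)Nc1cc(OC)ccc1C(=O)c1ccc2c(c1)C=CC(C)(C)O2`) has not been measured yet. It differs from compound 2 in one group (ethylamino in place of bromo on a saturated chain carbon bound to a carbonyl carbon), with ethylamino in place of bromo on a saturated chain carbon bound to a carbonyl carbon. For the measured compounds named here, no two measured compounds differ by this change alone, so the data offer no direct measure of it. Going by the values given here, the only guide is the narrow spread of the three values, which runs from compound 3 at 890 nM to compound 2 at 1870 nM and nothing wider. In this assay the expected step (a 1.2-fold lower number from compound 2 to compound 4 (0.10 log units; within the scatter)) is small, leaning slightly lower and estimated to stay within the scatter. For compound 4 the estimated value is 1500 nM (expected range 500 nM to 4500 nM).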

Compound 4, half-maximal inhibitory concentration: 2070 nM
Beside the measured number, compound 4's estimate is 1.4-fold (0.14 log units) below it; low and high end bracket the measured number.
By their numbers in this assay, from the lowest: compounds 3, 1, 2 and 4 (each within the scatter of the next, the first and the last beyond it).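

In this assay, for the compounds shown here, the swap of bromo for ethylamino on a saturated chain carbon bound to a carbonyl carbon gives a 1.1-fold higher number from compound 2 to compound 4 (0.04 log units; within the scatter) and so leaves compound 2 and compound 4 indistinguishable, which is the first direct reading of any change at this position. On paper the swap is not a trivial one: a single bromine leaves, while an ethylamino group of 3 heavy atoms enters with 1 hydrogen-bond donor and 1 hydrogen-bond acceptor, and still this read-out shows no difference beyond the usual scatter of repeated measurements. Nothing measured alongside these numbers speaks to why the two compounds read alike. 

The compounds shown carry only bromo, amino and ethylamino on this carbon, so one swap cannot say whether the position would tolerate any group, and a dimethylamino group, a longer chain such as butylamino or a morpholine ring could still read differently. Ethylamino also appears here only on the core of compound 2, which leaves open whether the same swap would read alike on the core of compound 1.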